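Acrylonitrile amides: pyrrole to furan on the chain carbon

The source may report more compounds than this note shows. Statements on the series, on what has been measured and on what is new or still open speak of the compounds shown alone.

Compound 1 `N#C/C(=C\c1c[nH]c2ccccc12)C(=O)c1c[nH]c2ccccc12` gives 8300 nM in a functional assay on SW480 cells (Homo sapiens) for inhibition, read by MTT assay, with a stated time of 72 h; a higher number here means a weaker inhibitor of growth, a lower number a stronger inhibitor of growth.
Compound 2 `COc1ccc(CNC(=O)/C(C#N)=C/c2ccc[nH]2)cc1` gives > 50000 nM in this assay, a limit of the assay and not a number.
Compound 3 `N#C/C(=C\c1ccco1)C(=O)NCc1ccc(Cl)c(Cl)c1` gives > 50000 nM in this assay, a limit as well.

Compound 2 stands at the limit of > 50000 nM in this assay, at which 2 of the 3 values shown sit; only compound 1 gives a measurable number. Compound 4 `COc1ccc(CNC(=O)/C(C#N)=C/c2ccoc2)cc1` differs from compound 2 by furan-3-yl in place of 1H-pyrrol-2-yl on a double-bonded chain carbon bound to a double-bonded chain carbon. Among the compounds with values here, no measured pair shows this change, so its size cannot be read from the data. Compound 3 sits at the limit of > 50000 nM in this assay, at which 2 of the 3 values shown sit, too, and compound 4 is expected to remain at that limit, so the step from compound 2 to compound 4 in this assay is expected to be a number no higher from compound 2 to compound 4 (the limit leaves the size open), nothing beyond the scatter. Compound 4 is estimated at 50000 nM, within a range from 20000 nM to 100000 nM, most likely reported only as a limit.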

Compound 4, concentration for 50% growth inhibition: 8000 nM
Estimate against measurement, compound 4: 6.3-fold (0.80 log units) above, outside the stated range (below it).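

In this assay, furan-3-yl in place of 1H-pyrrol-2-yl on a double-bonded chain carbon bound to a double-bonded chain carbon gives an at least 6.2-fold lower number from compound 2 to compound 4 (0.79 log units; beyond the scatter), so this position responds to the ring placed on it. On these data alone, the true size stays open, with compound 2 held at a limit and not a number: the limit of > 50000 nM in this assay, at which 2 of the 4 values shown sit. The amide part of compound 2, unchanged in compound 4, does not by itself hold a compound at that limit.

The change alters the hetero atom and the ring's point of attachment together, and these effects cannot be separated. A 1H-pyrrol-3-yl group in the same place would begin to separate them.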